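The source may hold more compounds than are shown below. What is called first, only, known or untested is meant among the compounds shown, and "the series" means these compounds.

Compound 1 `CCNC(=O)c1cc(N)c(Nc2ccc(C#N)cc2)cc1Oc1c(C)cc(/C=C/C#N)cc1C` carries an ethyl group on its amide-type nitrogen, and in a physicochemical assay for solubility, read by HPLC, with a stated time of 4 h, at pH 2 (a lower number here means a less soluble compound, a higher number a more soluble compound), compound 1 gives 69.4 ug/mL. Compound 2 `Cc1cc(/C=C/C#N)cc(C)c1Oc1cc(Nc2ccc(C#N)cc2)c(N)cc1C(=O)NN` differs from it only in having an amino group on that nitrogen, and in this assay compound 2 gives 89.6 ug/mL. Among the measured compounds shown here, the change reads as a 1.3-fold higher number from compound 1 to compound 2 (0.11 log units; within the scatter), so the two numbers cannot be told apart, and compound 2 stands level with compound 1 on the numbers so far. Compound 3 `Cc1cc(/C=C/C#N)cc(C)c1Oc1cc(Nc2ccc(C#N)cc2)c(N)cc1C(=O)N1CC1` takes the next step: aziridin-1-yl in place of aminoamino on a carbonyl carbon. For the measured compounds named here, the only measured step at this position is the one from compound 1 to compound 2, and it stayed within the scatter, so no step beyond the scatter is expected in this assay here either, though nothing measured rules out a modest drop. Compound 3 is therefore expected to give about 60 ug/mL, within a range from 25 ug/mL to 150 ug/mL. That estimate means an expected step of a 1.5-fold lower number from compound 2 to compound 3 (0.17 log units; within the scatter).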

Compound 3, solubility: 94.2 ug/mL
Beside the measured number, compound 3's estimate is 1.6-fold (0.20 log units) below it; measured number inside the range.
By their numbers in this assay, from the lowest: compounds 1, 2 and 3 (each within the scatter of the next).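

The aziridin-1-yl group brings a three-membered ring onto the carbonyl carbon and has no hydrogen-bond donors, unlike aminoamino, yet the result in this assay is a 1.1-fold higher number from compound 2 to compound 3 (0.02 log units; within the scatter) and stays equally flat against the ethyl-bearing starting point, at a 1.4-fold higher number from compound 1 to compound 3 (0.13 log units; within the scatter) in the same read-out. This position has therefore now taken an open chain, a nitrogen-linked amino group and a small ring with no step beyond the scatter, and all three compounds stand level. No measurement shown gives a reason for this flat result.

On these data alone, whether a larger ring such as piperidin-1-yl, a longer chain or a group carrying a carboxylic acid would also stay level on this carbonyl carbon remains open. A basic amine in that place is equally untested among the compounds shown.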